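Cytotoxicity notes on the triazole-ether series

This account rests on a few compounds, and the source may have more. Where it says the series, first, only, none or still open, it means among the compounds named here.

For the measured compounds named here, in an ADME assay on cells (Macrophage) for cytotoxicity, read by resazurin assay, with a stated time of 48 h (on this read-out higher numbers stand for lower toxicity in this test and lower numbers for higher toxicity in this test), compound 2 `COc1ccc(-c2cc(-c3ccc(OCc4cn(Cc5ccccc5)nn4)cc3O)nc(N)n2)cc1` gives 42700 nM, the only number in this set; in this assay compound 1 `CCCCCCn1cc(COc2ccc(-c3cc(-c4ccc(OC)cc4)nc(N)n3)c(O)c2)nn1` gives "not determined" (no result reported) and compound 3 `O=C(/C=C/c1cccc2ccccc12)c1ccc(OCc2cn(Cc3ccc(Br)cc3)nn2)cc1O` gives "not determined" (no result reported), so compound 2 stands alone rather than high or low against anything. Going by the values given here, no pair of measured compounds differs in a single place, so no step size is known from the data. Compound 4 `Nc1nc(-c2ccc(Cl)cc2)cc(-c2ccc(OCc3cn(Cc4ccccc4)nn3)cc2O)n1` differs from compound 2 by chloro in place of methoxy on an aromatic carbon. The expectation is a step of a 1.2-fold lower number from compound 2 to compound 4 (0.09 log units; within the scatter) that stays inside the usual scatter, with no direction beyond it supported by the data. Compound 4 is therefore estimated at 35000 nM in this assay, within a range from 14000 nM to 90000 nM.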

Compound 4, half-maximal cytotoxic concentration: 66600 nM
The estimate for compound 4 lay 1.9-fold (0.28 log units) below the measured number, and the stated range covers the measured number.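

Chloro in place of methoxy, 4-methoxyphenyl to 4-chlorophenyl, gives a 1.6-fold higher number from compound 2 to compound 4 (0.19 log units; within the scatter) in this assay. For the compounds shown here, this is the first measured step in the set, and it shows that this exchange on an aromatic carbon para to a large group does not separate the two compounds on this read-out. Nothing measured here bears on the reason for this result.

From the compounds shown here alone, whether an amine, a carboxylic acid or a longer alkoxy chain at this position would move the number beyond the scatter remains open. So does whether the same exchange behaves alike on a different triazole substituent.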